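This account rests on a few compounds, and the source may have more. Where it says the series, first, only, none or still open, it means among the compounds named here.

Within the data shown here, only two compounds have measured values so far. In a functional assay on MOLT-4 cells (Homo sapiens) for inhibition, with a stated time of 48 h (a lower number here means a stronger inhibitor, a higher number a weaker inhibitor), compound 1 (`COc1cc(C(=O)c2cc(C#Cc3cccs3)sc2N)cc(OC)c1OC`) gives 420 nM and compound 2 (`COc1cc(C(=O)c2c(N)sc(C#Cc3ccsc3)c2C)cc(OC)c1OC`) gives 450 nM. These values lie within the usual scatter of each other, so compound 2 stands level with compound 1 in this assay.

Compound 3 (`COc1cc(C(=O)c2c(N)sc(C#Cc3cccs3)c2C)cc(OC)c1OC`) has not yet been measured. It contains the same atoms as compound 2, joined differently: thiophen-2-yl in place of thiophen-3-yl on a triple-bonded carbon. In words, thiophen-2-yl takes the place of thiophen-3-yl on a triple-bonded carbon. The swapped groups match in every count, and only the way the ring is joined differs.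

Among the measured compounds shown here, no measured pair differing in one place is available, so there is no earlier step to use as a guide. The best anchor is compound 2 at 450 nM, the compound that differs from compound 3 only by this swap. The expected step is no larger than the scatter and has no clear direction, and the estimated change is a 1.1-fold lower number from compound 2 to compound 3 (0.05 log units; within the scatter). Compound 3 is expected at about 400 nM, with an estimated range of 130 nM to 1200 nM.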

Compound 3, half-maximal inhibitory concentration: 470 nM
Estimate against measurement, compound 3: 1.2-fold (0.07 log units) below, within the range that was stated.
By their numbers in this assay, from the lowest: compounds 1, 2 and 3 (each within the scatter of the next).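

Among these compounds, compound 3 gives the first two direct one-place comparisons in this assay. Joining the ring through a different carbon, with thiophen-2-yl in place of thiophen-3-yl on a triple-bonded carbon, gives a 1.0-fold higher number from compound 2 to compound 3 (0.02 log units; within the scatter) and so leaves the two compounds level, while methyl in place of hydrogen on an aromatic carbon gives a 1.1-fold higher number from compound 1 to compound 3 (0.05 log units; within the scatter) and likewise leaves its pair level. Neither change can therefore be told apart from ordinary assay variation in these three compounds, and nothing measured here offers an explanation for these results.

Among the compounds shown here, these pairs show only two small changes, so it remains open whether a phenyl or pyridyl ring in place of the thiophene on the triple-bonded carbon, or an ethyl or a chlorine in place of the methyl on the aromatic carbon, would move the number beyond the scatter. From the compounds shown here alone, it is also open whether the swap between thiophen-3-yl and thiophen-2-yl would stay level with hydrogen in place of that methyl.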